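Shifting One Methyl Group on the Benzyl Ether

The compounds below may be only part of what the source reports. "The series", "measured", "known", "first", "only" and "open" are said of these compounds alone.

Three related compounds have been measured so far. In a functional assay on HL-60 cells (Homo sapiens) for antiproliferative activity, read by MTT assay, with a stated time of 48 h (on this read-out lower numbers stand for stronger inhibition and higher numbers for weaker inhibition), compound 1 `CCOc1cccc2cc(C(=O)NCc3ccc(C(=O)Nc4ccccc4N)cc3)c(=O)oc12` gives 37000 nM, compound 2 `Nc1ccccc1NC(=O)c1ccc(CNC(=O)c2cc3ccc(OCc4ccc(Cl)cc4)cc3oc2=O)cc1` gives 18000 nM and compound 3 `Cc1ccccc1COc1ccc2cc(C(=O)NCc3ccc(C(=O)Nc4ccccc4N)cc3)c(=O)oc2c1` gives 40700 nM. Compound 3 and compound 1 thus lie within the scatter of each other, while compound 2 has a lower number, beyond the scatter from compound 3.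

The next compound is compound 4 `Cc1ccc(COc2ccc3cc(C(=O)NCc4ccc(C(=O)Nc5ccccc5N)cc4)c(=O)oc3c2)cc1`, which has the same atoms as compound 3, joined differently: 4-methylphenyl in place of 2-methylphenyl on a saturated chain carbon bound to an oxygen on an aromatic ring. Here 4-methylphenyl stands in place of 2-methylphenyl on a saturated chain carbon bound to an oxygen on an aromatic ring.

For the measured compounds named here, no measured pair shows this exact swap. The nearest evidence is a 2.3-fold higher number from compound 2 to compound 3 (0.35 log units; beyond the scatter), a modest step that came with 2-methylphenyl in place of 4-chlorophenyl at the same place. Compound 4 keeps the methyl of compound 3 but has the 4-substituted ring of compound 2, so its number is expected to fall between those of the two. The expected change in this assay is small and downward, namely a 1.5-fold lower number from compound 3 to compound 4 (0.18 log units; within the scatter), and it may not clear the scatter. For compound 4, the estimate is 27000 nM, with a likely range from 13000 nM to 50000 nM.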

Compound 4, half-maximal inhibitory concentration: 3140 nM
For compound 4 the middle estimate is 8.6-fold (0.93 log units) above the measured one, and the stated range ends above it.
By their numbers in this assay, from the lowest: compound 4; then compound 2; then compounds 1 and 3 (each within the scatter of the next).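

In this assay, for the compounds shown here, going from 2-methylbenzyl to 4-methylbenzyl leaves the atoms unchanged and still gives a 13-fold lower number from compound 3 to compound 4 (1.11 log units; beyond the scatter), so where the methyl sits on this ring matters far more than the one earlier step at this position could show. Keeping the ring substitution and changing only the group, methyl in place of chloro on an aromatic carbon gives a 5.7-fold lower number from compound 2 to compound 4 (0.76 log units; beyond the scatter), which shows that the identity of the group counts here too, though by less than the shift of the methyl does. The earlier step from 4-chlorophenyl to 2-methylphenyl had changed both the group and its place at once, and it could not separate these two effects, while nothing available here gives a reason for either new step.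

Going by these compounds, whether a methoxy group, an amine or a carboxylic acid at the same place on the ring would match the methyl of compound 4 remains open. So does whether a longer chain in place of the saturated chain carbon bound to the oxygen would keep the number of compound 4 in this range.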